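Notes on a brominated diaryl ether series: compound 4

A few compounds are considered here, and "the series" means these few. Any claim that something is new, unique, unknown or untested is made for them only; others in the source may bear on it.

Measured in a functional assay on U-937 cells (Homo sapiens) for cytotoxicity, read by MTT assay, with a stated time of 24 h; a lower number here means a stronger inhibitor, a higher number a weaker inhibitor:
compound 1 `BrCCCOc1c(Br)cc(Br)cc1Oc1ccc(Br)cc1Br` gives 30.3 ug/mL
compound 2 `COc1c(Br)cc(Br)cc1Oc1ccc(Br)cc1Br` gives 34.5 ug/mL
compound 3 `CC(C)(C)C(=O)C(C#N)Oc1c(Br)cc(Br)cc1Oc1ccc(Br)cc1Br` gives 32.5 ug/mL

Compound 1 holds the lowest of the three numbers, but a 1.1-fold higher number from compound 1 to compound 2 (0.06 log units; within the scatter) and a 1.1-fold higher number from compound 1 to compound 3 (0.03 log units; within the scatter) both fall within the scatter, as does a 1.1-fold lower number from compound 2 to compound 3 (0.03 log units; within the scatter); the three compounds are not separable on these data.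

Compound 4 `OCCOc1c(Br)cc(Br)cc1Oc1ccc(Br)cc1Br` differs from compound 1 by hydroxy in place of bromomethyl on a saturated chain carbon, two bonds along the chain from an oxygen on an aromatic ring. Both measured steps bear on this position on the shared core: a 1.1-fold higher number from compound 1 to compound 2 (0.06 log units; within the scatter) removes the chain, and a 1.1-fold higher number from compound 1 to compound 3 (0.03 log units; within the scatter) exchanges it for a quite different group, and neither moves the number beyond the scatter. No step beyond the scatter is therefore expected for a 1.1-fold higher number from compound 1 to compound 4 (0.02 log units; within the scatter).

Compound 4 is expected to give about 32 ug/mL in this assay, with a range of 18 ug/mL to 58 ug/mL.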

Compound 4, half-maximal inhibitory concentration: 34.5 ug/mL
The estimate for compound 4 lay 1.1-fold (0.03 log units) below the measured number; measured number inside the range.
By their numbers in this assay, from the lowest: compounds 1, 3, 2 and 4 (each within the scatter of the next).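

In this assay the exchange of bromomethyl for hydroxy brings in a hydrogen-bond donor and acceptor, yet it gives a 1.1-fold higher number from compound 1 to compound 4 (0.06 log units; within the scatter) and so stays within the scatter. Alongside it stand a 1.1-fold higher number from compound 3 to compound 4 (0.03 log units; within the scatter) and no change at the digits printed from compound 2 to compound 4 (within the scatter) as further steps within the scatter, so the four compounds remain inseparable at this position. No measurement at hand offers an explanation for this result.

On these data alone, whether an amine or a carboxylic acid in place of hydroxy on this chain would move the number beyond the scatter stays open. So does the outcome for a longer chain ending in hydroxy.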